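Moving the ketone aryl from 4-fluorophenyl to 3-bromophenyl

This account rests on a few compounds, and the source may have more. Where it says the series, first, only, none or still open, it means among the compounds named here.

Measured in an assay on isolated protein for inhibition of histone deacetylase HD2 (Zea mays); on this read-out lower numbers stand for stronger inhibition and higher numbers for weaker inhibition:
compound 1 `Cn1cc(/C=C/C(=O)c2ccccc2F)cc1/C=C/C(=O)NO`: 7100 nM
compound 2 `Cn1cc(/C=C/C(=O)c2ccc(F)cc2)cc1/C=C/C(=O)NO`: 35300 nM

Among the measured compounds shown here, compound 2 holds the highest number of the two, its only neighbour being compound 1: a 5.0-fold higher number from compound 1 to compound 2 (0.70 log units; beyond the scatter). Compound 3 `Cn1cc(/C=C/C(=O)c2cccc(Br)c2)cc1/C=C/C(=O)NO` is not yet measured; the change is 3-bromophenyl in place of 4-fluorophenyl on a carbonyl carbon. For the measured compounds named here, only that one step bears on it, and it concerns fluorine in another position, so it gives a loose guide at best. A modest move toward a lower number is therefore expected in this assay, a 2.4-fold lower number from compound 2 to compound 3 (0.37 log units; beyond the scatter). For compound 3 the estimated value is 15000 nM, within 4000 nM to 55000 nM.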

Compound 3, half-maximal inhibitory concentration: 2100 nM
Beside the measured number, compound 3's estimate is 7.1-fold (0.85 log units) above it; the measured number lies below the stated range.
By their numbers in this assay, from the lowest: compound 3; then compound 1; then compound 2.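

In this assay the change to 3-bromophenyl gives a 17-fold lower number from compound 2 to compound 3 (1.23 log units; beyond the scatter) and a 3.4-fold lower number from compound 1 to compound 3 (0.53 log units; beyond the scatter), which makes compound 3 the strongest of the three and shows that the aryl on this carbonyl carbon can move the number further than the two fluorophenyl compounds suggested. Halogen and ring placement change together in these steps, so their contributions cannot be separated. Nothing available explains the gain. Still open, on these data alone, is how 3-fluorophenyl or 4-bromophenyl would read here, and what an amine or a carboxylic acid on this aryl ring would do.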